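The source may hold more compounds than are shown below. What is called first, only, known or untested is meant among the compounds shown, and "the series" means these compounds.

Measured so far in a functional assay on DU-145 cells (Homo sapiens) for inhibition, read by trypan blue exclusion, with a stated time of 96 h; on this read-out lower numbers stand for stronger inhibition of growth and higher numbers for weaker inhibition of growth:
- compound 1 `COc1ccc(/C=C(/Sc2ccc(C)cc2)C(=O)c2ccc(Br)cc2)cc1` gives 50000 nM
- compound 2 `Cc1ccc(S/C(=C/c2cc(Cl)cc(Cl)c2Cl)C(=O)c2ccc(Cl)cc2)cc1` gives 50000 nM
- compound 3 `Cc1ccc(S/C(=C/c2ccc(Cl)cc2Cl)C(=O)c2ccc(Cl)cc2)cc1` gives 10000 nM

Compound 3 has the lowest number of the three, and both other compounds lie higher by a margin beyond the scatter.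

The next compound is compound 4 `COc1ccc(/C=C(/Sc2ccc(C)cc2)C(=O)c2ccc(Cl)cc2)cc1` with 4-methoxyphenyl in place of 2,4-dichlorophenyl on a double-bonded chain carbon bound to a double-bonded chain carbon. Within the data shown here, the only measured step at this place is the modest one, a 5.0-fold lower number from compound 2 to compound 3 (0.70 log units; beyond the scatter) and it involves a different pair of groups. Among the measured compounds shown here, compound 1 also carries 4-methoxyphenyl at this place and gives 50000 nM but it differs from compound 4 elsewhere, so no measured step isolates this group.

A modest rise in the number is therefore expected in this assay, meaning weaker inhibition of growth, with an estimated step of a 3.0-fold higher number from compound 3 to compound 4 (0.48 log units; beyond the scatter) in that direction. The estimate for compound 4 is 30000 nM (expected range 12000 nM to 70000 nM).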

Compound 4, concentration for 50% growth inhibition: 1000 nM
Estimate against measurement, compound 4: 30-fold (1.48 log units) above; measured number outside the range, below it.
By their numbers in this assay, from the lowest: compound 4; then compound 3; then compounds 1 and 2 (each within the scatter of the next).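

In this assay, the place on a double-bonded chain carbon bound to a double-bonded chain carbon proves far more responsive than the chlorinated aryl groups alone suggested: 4-methoxyphenyl in place of 2,4-dichlorophenyl gives a 10-fold lower number from compound 3 to compound 4 (1.00 log units; beyond the scatter), and in place of 2,3,5-trichlorophenyl it gives a 50-fold lower number from compound 2 to compound 4 (1.70 log units; beyond the scatter). The 4-methoxyphenyl group does not secure this level by itself, as chloro in place of bromo on an aromatic carbon gives a 50-fold lower number from compound 1 to compound 4 (1.70 log units; beyond the scatter), so a single halogen change with the aryl group held fixed matters strongly too. No measured evidence explains either step.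

Still open, going by these compounds, is whether the gain follows the methoxy group or the loss of chlorine, which plain phenyl or 4-hydroxyphenyl at this place would help separate. Fluoro on the aromatic carbon would show how far the halogen step extends.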